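The source may hold more compounds than are shown below. What is called first, only, known or untested is meant among the compounds shown, and "the series" means these compounds.

Three compounds built on a shared core were examined in a functional assay on HCT-15 cells (Homo sapiens) for cytotoxicity, read by CCK-8 assay and cell counting, with a stated time of 2 days; on this read-out higher numbers stand for weaker inhibition and lower numbers for stronger inhibition. Compound 1 `Oc1cccc(-c2cc(-c3ccccn3)nc(-c3ccccc3Cl)c2)c1` is recorded in this assay as "not determined" (no result reported), so no number exists for it. Compound 2 `Oc1ccc(-c2cc(-c3ccccc3)nc(-c3ccc(Cl)cc3)c2)cc1` gives 6920 nM in this assay, and compound 3 `Oc1ccc(-c2cc(-c3ccc(Cl)cc3)nc(-c3ccccn3)c2)cc1` gives 21300 nM. Compound 3 and compound 2 are joined by one change, (phenyl in place of pyridin-2-yl on an aromatic carbon), which made a 3.1-fold lower number from compound 3 to compound 2 (0.49 log units; beyond the scatter). Compound 1 and compound 3 are built from the same atoms joined differently; the difference between the two cores is not broken down here. Compound 4 `Oc1cccc(-c2cc(-c3ccccc3)nc(-c3ccccc3Cl)c2)c1` is not yet measured and differs from compound 1 by phenyl in place of pyridin-2-yl on an aromatic carbon. This is the same kind of change as that from compound 3 to compound 2, but the surroundings differ: in compound 1 the site is meta to a 2-chlorophenyl group and meta to a 3-hydroxyphenyl group, whereas in compound 3 it is meta to a 4-chlorophenyl group and meta to a 4-hydroxyphenyl group. Since compound 1 has no number, the step to compound 4 cannot be sized; the expectation for compound 4 rests on compound 2, which gives 6920 nM with the same phenyl in place. Compound 4 is expected to give about 8000 nM, estimated between 2500 nM and 30000 nM.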

Compound 4, half-maximal inhibitory concentration: 2930 nM
Beside the measured number, compound 4's estimate is 2.7-fold (0.44 log units) above it; the range from low to high includes it.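

No new step can be read: compound 1, which differs from compound 4 in one place, is recorded without a number. The compounds shown leave open whether phenyl in place of pyridin-2-yl at this site matches the step seen from compound 3 to compound 2. No evidence on hand accounts for compound 4's result.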